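Azetidine in Place of Bromoanilino on the Shared Core

The source may report more compounds than this note shows. Statements on the series, on what has been measured and on what is new or still open speak of the compounds shown alone.

The measured compounds and their values in a functional assay on ECa-109 cells for inhibition, with ECa-109 cell line (Homo sapiens) as the target, read by sulforhodamine B assay; on this read-out higher numbers stand for weaker inhibition and lower numbers for stronger inhibition:
Compound 1, `O=C1C=C(Nc2ccc(I)cc2)C(=O)c2c1nc1n2[C@H]2OC[C@@H](O)[C@H]2OC1`, gives 2300 nM.
Compound 2, `O=C1C=C(NCc2ccccc2)C(=O)c2c1nc1n2[C@H]2OC[C@@H](O)[C@H]2OC1`, gives only a limit of the assay, > 8000 nM.
Compound 3, `O=C1C=C(Nc2ccc(Br)cc2)C(=O)c2c1nc1n2[C@H]2OC[C@@H](O)[C@H]2OC1`, gives 2850 nM.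

Compound 3 stands highest of the two numbers, but its nearest neighbour is compound 1, and a 1.2-fold higher number from compound 1 to compound 3 (0.09 log units; within the scatter), so the two cannot be ordered. Compound 4, `O=C1C=C(N2CCC2)C(=O)c2c1nc1n2[C@H]2OC[C@@H](O)[C@H]2OC1`, differs from compound 3 by azetidin-1-yl in place of (4-bromophenyl)amino on a double-bonded ring carbon.

Going by the values given here, two measured steps bear on this change: an at least 3.4-fold higher number from compound 1 to compound 2 (0.54 log units; beyond the scatter) and an at least 2.8-fold lower number from compound 2 to compound 3 (0.44 log units; beyond the scatter). Both show that giving up the 4-halophenyl on the amine nitrogen for benzyl weakened inhibition beyond the scatter. Compound 4 goes further than compound 2, losing the aromatic ring and the hydrogen-bond donor together. The author therefore expects a weakening step in this assay, a 3.2-fold higher number from compound 3 to compound 4 (0.50 log units; beyond the scatter), with a real chance that the assay again reports only a limit, as it did for compound 2 at the limit of > 8000 nM in this assay, at which 1 of the 3 values shown sits.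

For compound 4 the estimate is 9000 nM, expected to fall between 3000 nM and 30000 nM.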

Compound 4, half-maximal inhibitory concentration: > 16000 nM
Compound 4: only a limit was reported; the forecaster's own chance of this, stated with the estimate: 55%; at least 1.7-fold (0.24 log units) between middle value and limit.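

In this assay, compound 4 is reported only as a limit: the limit of > 16000 nM in this assay, at which 1 of the 4 values shown sits. Azetidin-1-yl on this double-bonded ring carbon weakens inhibition beyond the scatter against both halogenated anilines, with an at least 5.6-fold higher number from compound 3 to compound 4 (0.74 log units; beyond the scatter) and an at least 6.9-fold higher number from compound 1 to compound 4 (0.84 log units; beyond the scatter), so among the four compounds only (4-bromophenyl)amino and (4-iodophenyl)amino give a measured number rather than a limit. The step from compound 2 to compound 4 cannot be read, as both values are limits, so the benzylamino and azetidin-1-yl groups cannot be ordered.

The change to compound 4 removes the aromatic ring and the hydrogen-bond donor together, and the compounds shown do not separate the two. A cyclobutylamino group, which keeps the amine hydrogen without the aromatic ring, or an N-methylanilino group, which keeps the ring without that hydrogen, would bear on this question.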